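A few compounds are considered here, and "the series" means these few. Any claim that something is new, unique, unknown or untested is made for them only; others in the source may bear on it.

Compound 1 `CC/C=C\C/C=C\C/C=C\CCCCCCCc1cc(=O)c2c(O)cc(OCOC)c(C)c2o1`: 6790 nM
Compound 2 `CC/C=C\C/C=C\C/C=C\CCCCCCCc1cc(=O)c2c(O)c(C)c(O)c(C)c2o1`: 6790 nM

In a functional assay on MDA-MB-231 cells (Homo sapiens) for antiproliferative activity, read by MTT assay (on this read-out lower numbers stand for stronger inhibition and higher numbers for weaker inhibition), compound 2 gives 6790 nM, which stands level with compound 1 within the scatter of repeated measurements. Compound 3 `CC/C=C\C/C=C\C/C=C\CCCCCCCc1cc(=O)c2c(O)c(C)c(OCOC)c(C)c2o1` has not yet been measured. It is compound 2 with one structural change: methoxymethyl in place of hydrogen on an oxygen on an aromatic ring, or hydroxy to methoxymethoxy. For the measured compounds named here, no measured step isolates this change. Compound 1 also carries a methoxymethoxy, and it gives 6790 nM, so no step beyond the scatter is expected here. The expected change, a 1.0-fold higher number from compound 2 to compound 3 (0.00 log units; within the scatter), would stay within the scatter in this assay, with no clear direction. For compound 3 the estimated value is 6800 nM, with an expected range from 3000 nM to 15000 nM.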

Compound 3, half-maximal inhibitory concentration: 16100 nM
Compound 3: the middle estimate sits 2.4-fold (0.37 log units) below what was measured; the whole stated range lies below it.
By their numbers in this assay, from the lowest: compounds 1 and 2 (each within the scatter of the next); then compound 3.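

In this assay, the change from hydroxy to methoxymethoxy on this oxygen on an aromatic ring is not neutral: it gives a 2.4-fold higher number from compound 2 to compound 3 (0.37 log units; beyond the scatter), a modest loss of inhibition that the methoxymethoxy already present in compound 1 had not revealed. The second comparison holds the methoxymethoxy in place and shows that methyl in place of hydrogen on an aromatic carbon gives a 2.4-fold higher number from compound 1 to compound 3 (0.37 log units; beyond the scatter), so the weaker value of compound 3 can be reached by either single change. Nothing available here explains either step.

As far as these compounds go, it remains open whether a plain methoxy, an ethoxy or an acetyl group on this oxygen would give a similar step. From the compounds shown here alone, it is also open whether methyl in place of hydrogen on that aromatic carbon would have the same effect alongside a free hydroxy.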